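This account rests on a few compounds, and the source may have more. Where it says the series, first, only, none or still open, it means among the compounds named here.

In an ADME assay on MT4 cells (Homo sapiens) for cytotoxicity, read by MTT assay (on this read-out higher numbers stand for lower toxicity in this test and lower numbers for higher toxicity in this test), compound 1 `O=C1c2ccccc2C(=O)N1CCOC(=S)N(C(=O)c1cccc([N+](=O)[O-])c1)c1ccc(Cl)cc1` gives 18000 nM and stands level with compound 2 `O=C1c2ccccc2C(=O)N1CCOC(=S)N(C(=O)c1ccc(Cl)cc1Cl)c1ccc(Cl)cc1`, which gives 18000 nM. These two differ on a carbonyl carbon, where 2,4-dichlorophenyl takes the place of 3-nitrophenyl, and that one measured step shows no change at the digits printed from compound 1 to compound 2 (within the scatter). Compound 3 `O=C1c2ccccc2C(=O)N1CCOC(=S)N(C(=O)c1cccc([N+](=O)[O-])c1)c1c(Cl)cccc1Cl` keeps the 3-nitrophenyl group of compound 1 and changes the other substituent: 2,6-dichlorophenyl in place of 4-chlorophenyl on an amide-type nitrogen. In words, 2,6-dichlorophenyl stands in place of 4-chlorophenyl on an amide-type nitrogen. Among the compounds with values here, no measured step touches that nitrogen substituent, so the evidence is indirect. The change on the carbonyl carbon left this assay unmoved, but it says nothing firm about this other place, and two compounds make a thin basis. With no measured sign of a direction, no shift beyond the scatter is expected, and the range is kept wide to reflect the untested change. What is expected is therefore no change at the digits printed from compound 1 to compound 3 (within the scatter). For compound 3 the estimated value is 18000 nM, with an expected range from 7000 nM to 45000 nM.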

Compound 3, half-maximal cytotoxic concentration: 58000 nM
Estimate against measurement, compound 3: 3.2-fold (0.51 log units) below, and the stated range ends below it.
By their numbers in this assay, from the lowest: compounds 1 and 2 (each within the scatter of the next); then compound 3.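

In this assay, the amide-type nitrogen proves to be a place where the read-out can move: 2,6-dichlorophenyl in place of 4-chlorophenyl gives a 3.2-fold higher number from compound 1 to compound 3 (0.51 log units; beyond the scatter), while the change on the carbonyl carbon gave no change at the digits printed from compound 1 to compound 2 (within the scatter). The step on the nitrogen is therefore the first among these compounds to lie beyond the scatter, although it is modest, and it points towards lower toxicity in this test. Nothing available bears on what lies behind this shift.

The compounds shown leave open whether the shift follows from the second chlorine or from where the chlorines stand on the ring, as 2,6-dichlorophenyl differs from 4-chlorophenyl in both respects, and a plain phenyl, a 2-chlorophenyl or a 4-methoxyphenyl on the same nitrogen would help to separate these readings. They also leave open whether 2,6-dichlorophenyl on the nitrogen would have the same effect alongside the 2,4-dichlorophenyl group of compound 2, as this single step was read only with 3-nitrophenyl on the carbonyl carbon.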